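One More Methoxy Group: Expected Effect on Cytotoxicity

A few compounds are considered here, and "the series" means these few. Any claim that something is new, unique, unknown or untested is made for them only; others in the source may bear on it.

Measured so far, in a functional assay on CAKI-1 cells (Homo sapiens) for cytotoxicity, read by sulforhodamine B assay, with a stated time of 48 h, tested at 100 uM; a lower number here means a stronger effect, a higher number a weaker effect of the compound at the concentration tested:
compound 1 `COc1ccc(C(=O)/C=C/c2cc(-c3cc(OC)c(OC)c(OC)c3)n[nH]2)cc1OC` gives -91%;
compound 2 `COc1ccc(C(=O)/C=C/c2cc(-c3cc(OC)c(OC)c(OC)c3)n[nH]2)cc1` gives 1%;
compound 3 `COc1cc(-c2cc(/C=C/C(=O)c3ccc(F)c(F)c3)[nH]n2)cc(OC)c1OC` gives 3%.

Compound 1 stands lowest of the three numbers and so shows the strongest effect. Its nearest neighbour is compound 2, reached by a number 92 percentage points higher from compound 1 to compound 2 (beyond the scatter), and compound 3 lies further still, reached by a number 94 percentage points higher from compound 1 to compound 3 (beyond the scatter). Compound 4 `COc1cc(C(=O)/C=C/c2cc(-c3cc(OC)c(OC)c(OC)c3)n[nH]2)cc(OC)c1OC` differs from compound 1 by methoxy in place of hydrogen on an aromatic carbon. Within the data shown here, no measured step adds a methoxy group; the steps that bear on the question are the two large ones just named, each of which changed the part of compound 1 that carries the carbonyl and each of which wiped out the effect. Between compound 2 and compound 3 the difference is only a number 2 percentage points higher from compound 2 to compound 3 (within the scatter). The new change goes the opposite way, adding rather than taking away, so a large loss is possible but not shown by any step, and the expectation leans toward keeping much of the effect of compound 1 with wide uncertainty. Compound 4 is therefore expected to give -40%, between -95% and 30%, an expected step of a number 51 percentage points higher from compound 1 to compound 4 (beyond the scatter).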

Compound 4, a percentage reported as activity, at one concentration (the size of the read-out at that concentration, not a potency): -94%
Estimate against measurement, compound 4: 54 percentage points above; measured number inside the range.
By their numbers in this assay, from the lowest: compounds 4 and 1 (each within the scatter of the next); then compounds 2 and 3 (each within the scatter of the next).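

On this aromatic carbon, ortho to a methoxy group, a hydrogen can give way to a methoxy group with no visible cost in this assay: compound 1 and compound 4 cannot be told apart, with a number 3 percentage points lower from compound 1 to compound 4 (within the scatter). Among these compounds, the earlier compounds showed only that taking a methoxy group off this ring can abolish the effect, with a number 92 percentage points higher from compound 1 to compound 2 (beyond the scatter), whereas this result shows that adding one here keeps the effect. No measurement is available to explain this result.

A single tested concentration cannot show whether compound 1 and compound 4 would also match at lower concentrations. As far as these compounds go, it also remains open whether this carbon would accept something other than methoxy, such as an ethoxy group, an amine or a carboxylic acid.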